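Methyl Gives Way to Iodo: Expecting Compound 3

The source may hold more compounds than are shown below. What is called first, only, known or untested is meant among the compounds shown, and "the series" means these compounds.

Of the compounds shown here, two have so far been tested in a functional assay on A549 cells (Homo sapiens) for antiproliferative activity, read by MTT assay, with a stated time of 72 h; on this read-out lower numbers stand for stronger inhibition and higher numbers for weaker inhibition. Compound 1 `O=C(Nc1ccccc1Br)C(Cl)Cl` gives 37000 nM, and compound 2 `Cc1cccc(NC(=O)C(Cl)Cl)c1` gives 41100 nM, the higher of the two numbers, though its gap to compound 1 lies within the usual scatter. Compound 3 `O=C(Nc1cccc(I)c1)C(Cl)Cl` is not yet measured. It differs from compound 2 by iodo in place of methyl on an aromatic carbon. Going by the values given here, no measured pair shows this change, so only a small step is expected, a 1.4-fold lower number from compound 2 to compound 3 (0.14 log units; within the scatter), toward a somewhat lower number but not clearly beyond the scatter. Compound 3 is therefore expected to give 30000 nM, within a range of 12000 nM to 80000 nM.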

Compound 3, half-maximal inhibitory concentration: 4760 nM
The estimate for compound 3 lay 6.3-fold (0.80 log units) above the measured number; measured number below the stated range.
By their numbers in this assay, from the lowest: compound 3; then compounds 1 and 2 (each within the scatter of the next).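

On an aromatic carbon meta to a group of 6 heavy atoms, iodo in place of methyl gives an 8.6-fold lower number from compound 2 to compound 3 (0.94 log units; beyond the scatter), so exchanging one heavy atom for another is enough here to move the number beyond the scatter. Until now, no measured pair had shown any step at this position. Nothing measured here tells why the number falls.

As far as these compounds go, it remains open whether iodo is unusual at this position, or whether an amine, a carboxylic acid or a methoxy group there would give a similar number. Also open, from the compounds shown here alone, is whether iodo would give the same step at another place on the ring.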